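Trading the Large Side Group of Compound 2 for a Small One

The source may hold more compounds than are shown below. What is called first, only, known or untested is meant among the compounds shown, and "the series" means these compounds.

Compound 1, `CC#C[C@H]1CN(S(=O)(=O)c2ccc(N)nc2)CCN1c1ccc(C(=O)NC)cc1`, gives 4050 nM in an assay on cells (Hepatocyte) for inhibition of glucokinase regulatory protein (Mus musculus), with stated times of 20 min and 40 min; on this read-out higher numbers stand for an effect only at larger amounts of compound and lower numbers for an effect already at smaller amounts.
Compound 2, `CC#C[C@H]1CN(S(=O)(=O)c2ccc(N)nc2)CCN1c1ccc(C(O)(CC#N)C(F)(F)F)cc1`, gives 219 nM in this assay.
Compound 3, `CC#C[C@H]1CN(S(=O)(=O)c2ccc(N)nc2)CCN1c1ccc(C(O)(C(F)(F)F)C(F)(F)F)cn1`, gives 421 nM in this assay.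

Among these three numbers in this assay compound 2 stands lowest. Its nearest neighbour is compound 3, whose number lies within the usual scatter of it, so the two cannot be told apart; compound 1 sits far beyond the scatter with a much higher number. Compound 4, `CC#C[C@H]1CN(S(=O)(=O)c2ccc(N)nc2)CCN1c1ccc([S+](C)[O-])cc1`, is not yet measured. It keeps the shared core and differs from compound 2 in one place: a group of 3 heavy atoms (1 carbon, 1 oxygen, 1 sulfur; no ring) in place of a group of 9 heavy atoms (4 carbon, 1 nitrogen, 1 oxygen, 3 fluorine; no ring), on an aromatic carbon.

Among the measured compounds shown here, only one measured step bears on this change. The step of an 18-fold lower number from compound 1 to compound 2 (1.27 log units; beyond the scatter) shows that putting the group of 9 heavy atoms onto this aromatic carbon in place of a group of 4 heavy atoms brought a large drop in number. Compound 4 goes the other way, removing that 9-atom group and leaving a group of only 3 heavy atoms, so a step back up toward the number of compound 1 is expected, though how far the new small group reaches cannot be known from these data. In this assay compound 4 is therefore estimated at 1500 nM, in the range 500 nM to 4500 nM, which means an expected step of a 6.8-fold higher number from compound 2 to compound 4 (0.84 log units; beyond the scatter).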

Compound 4, half-maximal effective concentration: > 12500 nM
Compound 4: a limit, no number; the forecaster's own chance of this, stated with the estimate: 5%; middle value at least 8.3-fold (0.92 log units) away from the limit.
By their numbers in this assay, from the lowest: compounds 2 and 3 (each within the scatter of the next); then compound 1. At a limit, above all of these: compound 4.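

Compound 4 carries a limit of the assay and not a number: the limit of > 12500 nM in this assay, at which 1 of the 4 values shown sits. Even so, the change on this aromatic carbon can be read, since the step of an at least 57-fold higher number from compound 2 to compound 4 (1.75 log units; beyond the scatter) is large and puts the group of 3 heavy atoms far from the group of 9 heavy atoms it replaces. Among the compounds shown here, the small group also does not simply return the number to where the earlier compounds left it, for the step of an at least 3.0-fold higher number from compound 1 to compound 4 (0.48 log units; beyond the scatter) lies beyond the scatter as well, so the earlier finding that a group at this place could lower the number in this assay now gains its counterpart: a group at the same place can also raise it past that of compound 1.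

As far as these compounds go, how far beyond the limit compound 4 really lies stays open. Also open, from the compounds shown here alone, is whether it is the small size of the new group or its sulfur and oxygen that matters, which an amine, a carboxylic acid or a short alkyl chain on this aromatic carbon could help to separate.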